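A pyridin-2-yl ether in place of the trifluoromethylphenyl ether

This account rests on a few compounds, and the source may have more. Where it says the series, first, only, none or still open, it means among the compounds named here.

Compound 1, `O=C1[C@H](NS(=O)(=O)c2ccc(Oc3ccccc3)cc2)CC=CCN1O`, in an assay on isolated protein for inhibition of matrix metalloproteinase-9 (Homo sapiens), read by fluorescence, with stated times of 1 h and 15 min (a higher number here means a weaker inhibitor, a lower number a stronger inhibitor), gives 2 nM.
Compound 2, `O=C1[C@H](NS(=O)(=O)c2ccc(Oc3ccc(C(F)(F)F)cc3)cc2)CC=CCN1O`, in this assay gives 2 nM.

Compound 2 stands level with compound 1 at the digits shown; the one step that connects them, no change at the digits printed from compound 1 to compound 2 (within the scatter), shows that exchanging hydrogen for trifluoromethyl on the distal aromatic ring left the number where it was. Compound 3 is `O=C1[C@H](NS(=O)(=O)c2ccc(Oc3ccccn3)cc2)CC=CCN1O`, and it is not yet measured in this assay. It differs from compound 2 in the same outer ring: pyridin-2-yl in place of 4-(trifluoromethyl)phenyl on an oxygen on an aromatic ring. For the measured compounds named here, the only step that bears on this place is no change at the digits printed from compound 1 to compound 2 (within the scatter), which was flat within the scatter, so the series so far gives no sign that this ring drives the number; at the same time the new ring is smaller and carries a nitrogen, and no measured pair covers that kind of exchange, so the expectation is wider than the one measured step alone would suggest. Compound 3 is therefore expected to stay close to compound 2, with a step of no change at the digits printed from compound 2 to compound 3 (within the scatter), and its estimated value in this assay is 2 nM, within a range of 0.7 nM to 6 nM.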

Compound 3, half-maximal inhibitory concentration: 23 nM
Compound 3: middle estimate off by 12-fold (1.06 log units), on the low side; the whole stated range lies below it.
By their numbers in this assay, from the lowest: compounds 1 and 2 (each within the scatter of the next); then compound 3.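

The outer ring on the oxygen proved less forgiving than the earlier pair suggested: in this assay the exchange for pyridin-2-yl gives a 12-fold higher number from compound 2 to compound 3 (1.06 log units; beyond the scatter) and, measured against the plain phenyl ether, a 12-fold higher number from compound 1 to compound 3 (1.06 log units; beyond the scatter) as well. Both steps start from compounds that print the same value, so the rise does not depend on whether the ring it replaces carries trifluoromethyl, and the feature found only in compound 3 is a ring nitrogen, counted as one hydrogen-bond acceptor. Nothing available here explains why the number rises with this exchange.

On these data alone, what remains open is whether any ring nitrogen on this oxygen raises the number or only one placed as in pyridin-2-yl, a question that the pyridin-3-yl and pyridin-4-yl ethers would address. As far as these compounds go, it is also open whether a trifluoromethyl or methoxy group carried on the pyridin-2-yl ring would bring the value back towards those of the two phenyl ethers, compound 1 and compound 2.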